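The source may report more compounds than this note shows. Statements on the series, on what has been measured and on what is new or still open speak of the compounds shown alone.

Of the compounds shown here, three have so far been measured in a functional assay on ECa-109 cells (Homo sapiens) for antiproliferative activity, read by MTT assay, with a stated time of 72 h; a lower number here means a stronger inhibitor, a higher number a weaker inhibitor. Compound 1 `CCCSc1nc(N/N=C(\C)c2ccc(O)cc2)c2nnn(Cc3ccccc3)c2n1` gives 32500 nM, compound 2 `CCCSc1nc(N/N=C(\C)c2ccccc2O)c2nnn(Cc3ccc(O)cc3)c2n1` gives 15900 nM, and compound 3 `C/C(=N\Nc1nc(SCc2ccccc2)nc2c1nnn2Cc1ccccc1)c1ccccc1O` gives 1770 nM, the lowest of the three numbers, with both other values lying beyond the usual scatter of it. Compound 4 `CCCSc1nc(N/N=C(\C)c2ccccc2O)c2nnn(Cc3ccccc3)c2n1` is the next compound and differs from compound 3 by ethyl in place of phenyl on a saturated chain carbon bound to a sulfur. Among the measured compounds shown here, compounds 1 and 2 also carry propylsulfanyl, and both give higher numbers than compound 3; on that showing, a step upward beyond the scatter is expected here, though no directly comparable pair has been measured. Compound 4 is expected to give 8000 nM, within a range from 3000 nM to 25000 nM. The expected step from compound 3 to compound 4 is a 4.5-fold higher number from compound 3 to compound 4 (0.66 log units; beyond the scatter), a loss of potency rather than a gain.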

Compound 4, half-maximal inhibitory concentration: 11100 nM
Compound 4: middle estimate off by 1.4-fold (0.14 log units), on the low side; the range from low to high includes it.
By their numbers in this assay, from the lowest: compound 3; then compounds 4 and 2 (each within the scatter of the next); then compound 1.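

Among the compounds shown here, the first direct comparison at this position shows that benzylsulfanyl in place of propylsulfanyl matters in this assay (a 6.3-fold higher number from compound 3 to compound 4 (0.80 log units; beyond the scatter)). With propylsulfanyl held fixed, hydrogen in place of hydroxy on an aromatic carbon stays within the scatter (a 1.4-fold lower number from compound 2 to compound 4 (0.16 log units; within the scatter)), while 2-hydroxyphenyl in place of 4-hydroxyphenyl goes beyond it (a 2.9-fold lower number from compound 1 to compound 4 (0.47 log units; beyond the scatter)). No measurement here explains these steps. The compounds shown leave open whether pentylsulfanyl or cyclohexylmethylsulfanyl in place of benzylsulfanyl would give a number as low as that of compound 3.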